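Adding a second chloro to compound 1

The source may report more compounds than this note shows. Statements on the series, on what has been measured and on what is new or still open speak of the compounds shown alone.

Measured in a functional assay on MCF7 cells (Homo sapiens) for antiproliferative activity, read by MTT assay, with a stated time of 48 h (a higher number here means a weaker inhibitor, a lower number a stronger inhibitor), so far
Compound 1 `Clc1ccc2[nH]c(-c3cn(-c4ccccc4)nc3-c3ccccc3)nc2c1` gives 1960 nM here
Compound 2 `FC(F)(F)c1ccc2[nH]c(-c3cn(-c4ccccc4)nc3-c3ccccc3)nc2c1` gives 2660 nM here

Going by the values given here, the step of a 1.4-fold higher number from compound 1 to compound 2 (0.13 log units; within the scatter) lies within the scatter, so compound 1 stands level with the only other compound measured. Compound 3 `Clc1cc2nc(-c3cn(-c4ccccc4)nc3-c3ccccc3)[nH]c2cc1Cl` keeps the core of compound 1 and takes chloro in place of hydrogen on an aromatic carbon, ortho to a chloro group. Among the compounds with values here, the one measured step exchanges one group for another and adds none, so it bears only loosely on this change. Its small size gives no ground to expect a step beyond the scatter in this assay for this addition. The estimated step is a 1.2-fold lower number from compound 1 to compound 3 (0.09 log units; within the scatter) and stays within the scatter. For compound 3 the estimated value is 1600 nM with an expected range of 700 nM to 3600 nM in repeated measurements.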

Compound 3, half-maximal inhibitory concentration: 7560 nM
Estimate against measurement, compound 3: 4.7-fold (0.67 log units) below, outside the stated range (above it).
By their numbers in this assay, from the lowest: compounds 1 and 2 (each within the scatter of the next); then compound 3.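

In this assay, adding chloro on this aromatic carbon, ortho to a chloro group, gives a 3.9-fold higher number from compound 1 to compound 3 (0.59 log units; beyond the scatter), a modest weakening. The earlier exchange of chloro for trifluoromethyl had stayed within the scatter, so this addition is the first change shown to move the number beyond it. No measurement at hand accounts for this step.

Going by these compounds, whether the weakening belongs to chloro itself or to any group on this carbon stays open. A fluoro or methoxy group here would bear on that question.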